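Removing the anilide nitro group in the bis-benzylidene series

This account rests on a few compounds, and the source may have more. Where it says the series, first, only, none or still open, it means among the compounds named here.

Measured so far in a functional assay on Molt4/C8 cells (Homo sapiens) for cytotoxicity; a lower number here means a stronger inhibitor, a higher number a weaker inhibitor:
compound 1 `O=C(/C=C/C(=O)N1C/C(=C\c2ccccc2)C(=O)/C(=C/c2ccccc2)C1)Nc1ccc([N+](=O)[O-])cc1` — 31000 nM
compound 2 `O=C(/C=C/C(=O)N1C/C(=C\c2ccc([N+](=O)[O-])cc2)C(=O)/C(=C/c2ccc([N+](=O)[O-])cc2)C1)Nc1ccc(Cl)c(Cl)c1` — 600 nM
compound 3 `CC(=O)c1ccc(NC(=O)/C=C/C(=O)N2C/C(=C\c3ccc([N+](=O)[O-])cc3)C(=O)/C(=C/c3ccc([N+](=O)[O-])cc3)C2)cc1` — 390 nM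

Compound 1 gives the highest number of the three in this assay; compound 2 and compound 3 both sit beyond the scatter below it, while their own difference, a 1.5-fold lower number from compound 2 to compound 3 (0.19 log units; within the scatter), is within it. Compound 4 `O=C(/C=C/C(=O)N1C/C(=C\c2ccccc2)C(=O)/C(=C/c2ccccc2)C1)Nc1ccccc1` differs from compound 1 by hydrogen in place of nitro on an aromatic carbon. Among the measured compounds shown here, no measured step changes this position on this core; the only step on the amide-type nitrogen, from compound 2 to compound 3, swaps one aryl group for another on a different core and is small. A step of no size beyond the scatter is therefore expected, a 1.0-fold lower number from compound 1 to compound 4 (0.01 log units; within the scatter). Compound 4 is estimated at 30000 nM, in the range 10000 nM to 90000 nM.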

Compound 4, half-maximal inhibitory concentration: 520 nM
The estimate for compound 4 lay 58-fold (1.76 log units) above the measured number, and the stated range ends above it.
By their numbers in this assay, from the lowest: compounds 3, 4 and 2 (each within the scatter of the next); then compound 1.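

In this assay the change from 4-nitrophenyl to phenyl gives a 60-fold lower number from compound 1 to compound 4 (1.78 log units; beyond the scatter) and so shows that this position matters on this core. Among the compounds shown here, the earlier compounds offered no step here, and the single amide-side step among them stayed within the scatter. No measurement at hand accounts for the size of this step.

On these data alone, whether an amine or a methoxy group at this position stays close to compound 4 or moves towards compound 1 remains open. Also open, as far as these compounds go, is whether removing the nitro group has a similar effect on the core of compound 3.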